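A few compounds are considered here, and "the series" means these few. Any claim that something is new, unique, unknown or untested is made for them only; others in the source may bear on it.

Measured compounds: compound 1 `N#Cc1ccccc1C1CCN(CCCNC(=O)C2=CNC(=O)N[C@@H]2c2ccc(F)c(F)c2)CC1` gives 0.717 h; compound 2 `CC1=C(C(=O)NCCCN2CCC(c3ccccc3C#N)CC2)[C@@H](c2ccc(F)c(F)c2)NC(=O)N1` gives 2.7 h; compound 3 `CC1=C(C(=O)NCCCN2CCC(c3ccc(F)cc3C#N)CC2)[C@@H](c2ccc(F)c(F)c2)NC(=O)N1C` gives 2.2 h, all in an ADME assay on the whole organism with Rattus norvegicus as the target; a lower number here means that the compound disappears faster, a higher number that the compound lasts longer.

Compound 2 and compound 1 share a core and differ only by hydrogen in place of methyl on a double-bonded ring carbon, a change that gave a 3.8-fold lower number from compound 2 to compound 1 (0.58 log units; beyond the scatter). The core of compound 3 differs from that of compound 2, and that difference is not broken down here; the values of compound 2 and compound 3 lie within the scatter of each other in this assay.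

Compound 4 `CN1C=C(C(=O)NCCCN2CCC(c3ccc(F)cc3C#N)CC2)[C@@H](c2ccc(F)c(F)c2)NC1=O` is not yet measured. It differs from compound 3 by hydrogen in place of methyl on a double-bonded ring carbon. This is the same kind of change as from compound 2 to compound 1, though here the place is also next to the ring atom that bears a methyl group. The earlier step, a 3.8-fold lower number from compound 2 to compound 1 (0.58 log units; beyond the scatter), is the basis for expecting a shortening of the same kind. Compound 4 is therefore expected to show a 2.8-fold lower number from compound 3 to compound 4 (0.44 log units; beyond the scatter) in this assay. The estimated value of compound 4 is 0.8 h, expected between 0.4 h and 1.6 h.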

Compound 4, half-life: 0.8 h
For compound 4 middle estimate and measured number coincide at the digits printed; the range from low to high includes it.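

Hydrogen in place of methyl on a double-bonded ring carbon gave a 2.8-fold lower number from compound 3 to compound 4 (0.44 log units; beyond the scatter) in this assay. The change thus carried from one core to the other with a similar size: the same change on two cores in this assay, a 3.8-fold lower number (0.58 log units; beyond the scatter) from compound 2 to compound 1 and a 2.8-fold lower number (0.44 log units; beyond the scatter) from compound 3 to compound 4, 1.4-fold (0.14 log units) apart, within the scatter of two such steps. Among the compounds shown here, this agreement rests on only two pairs, so it does not show that the change would act alike on other cores of the series, and it gives no reason for the shorter half-life.

The compounds shown carry only hydrogen or methyl on that ring carbon. They leave open how an ethyl or a methoxymethyl group in that place would fare in this assay.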